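A Chloro Step from a Compound at the Limit

The compounds below may be only part of what the source reports. "The series", "measured", "known", "first", "only" and "open" are said of these compounds alone.

Compound 1 (`CCOC(=O)/C=C/C=C/c1ccc[nH]1`) was tested in a functional assay on CCRF-CEM cells (Homo sapiens) for cytotoxicity, with a stated time of 72 h; on this read-out higher numbers stand for weaker inhibition and lower numbers for stronger inhibition. There compound 1 gives > 10000 nM, which is a limit of the assay and not a number. Compound 2 (`CCOC(=O)/C=C/C=C/C=C/c1ccco1`) gives > 10000 nM in this assay, again a limit. Compound 3 (`CCOC(=O)/C=C/C=C/C=C/C=C/c1ccco1`) gives > 10000 nM in this assay, also a limit. Compound 1 thus has no number of its own, and the series offers only (the limit of > 10000 nM in this assay, at which 3 of the 3 values shown sit).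

Compound 4 (`CCOC(=O)/C=C/C=C/c1[nH]ccc1Cl`) carries chloro in place of hydrogen on an aromatic carbon, next to the ring atom that bears a group of 9 heavy atoms and two ring bonds from the ring nitrogen: chloro in place of hydrogen on an aromatic carbon.

Because the limit of > 10000 nM in this assay, at which 3 of the 3 values shown sit, no measured change gives a size to lean on. Only a small gain in this assay, or none beyond the scatter, is expected, and the estimated step is a number no higher from compound 1 to compound 4 (the limit leaves the size open). A reading at the limit again is quite likely. For compound 4 the estimated value is 10000 nM, with an expected range of 3000 nM to 30000 nM.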

Compound 4, half-maximal inhibitory concentration: > 10000 nM
Compound 4: only a limit was reported; the forecaster's own chance of this, stated with the estimate: 65%; the middle value lies on the limit itself.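

In this assay, going by these compounds alone, compound 4 gives a limit of the assay, as compound 1 does, so no step between compound 1 and compound 4 can be read: the limit of > 10000 nM in this assay, at which 4 of the 4 values shown sit. The compounds shown leave open whether chloro in place of hydrogen on an aromatic carbon changes cytotoxicity at all.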